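Pyrazinyl Amine Variant of a Benzimidazole Liver Microsome Series

A few compounds are considered here, and "the series" means these few. Any claim that something is new, unique, unknown or untested is made for them only; others in the source may bear on it.

Measured compounds:
compound 1, `COc1cccc(Nc2cc3[nH]c(-c4cccc(C(F)(F)F)c4)nc3cn2)n1`: 45%
compound 2, `COc1cccnc1Nc1cc2[nH]c(-c3cccc(C(F)(F)F)c3)nc2cn1`: 69%

In an ADME assay on microsomes from liver (Homo sapiens) for metabolic stability, read by LC-MS, with a stated time of 30 min, tested at 0.1 uM (a lower number here means that less of the compound is left, a higher number that more of the compound is left), compound 1 gives 45%, the lower of the two numbers available. Its nearest neighbour is compound 2, reached by the change a number 24 percentage points higher from compound 1 to compound 2 (beyond the scatter), a move beyond the scatter.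

Compound 3, `FC(F)(F)c1cccc(-c2nc3cnc(Nc4cnccn4)cc3[nH]2)c1`, has not yet been measured in this assay. Compound 3 differs from compound 1 as follows: pyrazin-2-yl in place of 6-methoxypyridin-2-yl on a nitrogen on an aromatic ring. Among the compounds with values here, no measured step covers this kind of exchange. Within the data shown here, the single step from compound 1 to compound 2 only moves the methoxy group within the same pyridinyl ring, and that step is modest. The expectation for compound 3 therefore rests on little more than the value of compound 1, so a step in this assay is expected of about a number 10 percentage points higher from compound 1 to compound 3 (within the scatter), upward but uncertain in size. Compound 3 is estimated at 55%, within the range 35% to 75%.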

Compound 3, percent of the compound remaining: 43%
Compound 3: the middle estimate sits 12 percentage points above what was measured, within the range that was stated.
By their numbers in this assay, from the lowest: compounds 3 and 1 (each within the scatter of the next); then compound 2.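

In this assay, pyrazin-2-yl on the aromatic amine nitrogen gives a number 2 percentage points lower from compound 1 to compound 3 (within the scatter), so at this place the change from 6-methoxypyridin-2-yl to a ring with two hetero atoms and no methoxy group leaves no readable difference. Within the data shown here, the same group gives a number 26 percentage points lower from compound 2 to compound 3 (beyond the scatter), which makes 3-methoxypyridin-2-yl the only one of the three groups whose number stands clear of both others. No evidence is available that would explain these numbers.

The compounds shown leave open whether the methoxy group itself or the ring carrying it accounts for the standing of compound 2. They also leave open how an unsubstituted pyridin-2-yl, or a pyridin-2-yl carrying an ethoxy group or an amine in place of the methoxy group, would read in this assay.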